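Hydrazone Aryl Swap on a Quinazoline Urea Series

The source may hold more compounds than are shown below. What is called first, only, known or untested is meant among the compounds shown, and "the series" means these compounds.

Compound 1 `O=C(N/N=C/c1ccc(F)cc1)Nc1cc2c(Nc3ccc(F)c(Cl)c3)ncnc2cc1O[C@H]1CCOC1` is the reference point. In a functional assay on PC-3 cells (Homo sapiens) for cytotoxicity, read by MTT assay, with a stated time of 72 h (a lower number here means a stronger inhibitor, a higher number a weaker inhibitor), compound 1 gives "not active" (no number reported), so no single number fixes where it stands. Among the compounds with values here, compound 2 `N#Cc1ccc(/C=N/NC(=O)Nc2cc3c(Nc4ccc(F)c(Cl)c4)ncnc3cc2O[C@H]2CCOC2)cc1`, the only other member with a result, gives 28100 nM in this assay, a weak value. Compound 3 `COc1ccc(/C=N/NC(=O)Nc2cc3c(Nc4ccc(F)c(Cl)c4)ncnc3cc2O[C@H]2CCOC2)c(OC)c1OC` differs from compound 1 as follows: 2,3,4-trimethoxyphenyl in place of 4-fluorophenyl on a carbon with a double bond to nitrogen. Within the data shown here, no measured step of this kind exists, so any expectation is loose; a modest change in either direction, likely within the scatter, is expected. Compound 3 is estimated at 30000 nM in this assay, with a range from 8000 nM to 100000 nM.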

Compound 3, half-maximal inhibitory concentration: 25600 nM
Estimate against measurement, compound 3: 1.2-fold (0.07 log units) above; measured number inside the range.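

In this assay the exchange on a carbon with a double bond to nitrogen gives a 1.1-fold lower number from compound 2 to compound 3 (0.04 log units; within the scatter) and so separates 2,3,4-trimethoxyphenyl from 4-cyanophenyl by no more than the usual scatter. Compound 1 carries no number, so its change to compound 3 cannot be read. Nothing on hand accounts for this result.

Open, on these data alone, is whether an aryl ring carrying an amine or a carboxylic acid would shift the value. Also open, as far as these compounds go, is whether a saturated ring such as cyclohexyl in place of the aryl ring would do so.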